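Dimethylamino for chloro on the shared core

A few compounds are considered here, and "the series" means these few. Any claim that something is new, unique, unknown or untested is made for them only; others in the source may bear on it.

Working notes on a small set of compounds sharing one core. In an assay on HEK293 cells for agonist activity at Toll-like receptor 8 (Homo sapiens), read by reporter gene assay (a higher number here means that more compound is needed for the effect, a lower number that less compound is needed), compound 1 `CCCCCn1c(N)nc2c(C)cccc21` gives 1130 nM. Compound 2 `CCCCCn1c(N)nc2cccc(C)c21`, which carries its methyl group at a different site on the same core, gives 6610 nM in this assay. For the measured compounds named here, no step between these two is worked out here; the two values are simply what they show.

Compound 3 `CCCCCn1c(N)nc2c(Cl)cccc21` carries a chloro group where compound 1 carries methyl. In this assay compound 3 gives "not active" (no number reported) and no single number is available for it, so it cannot be placed on the scale shown by compounds 1 and 2.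

The next compound, compound 4 `CCCCCn1c(N)nc2c(N(C)C)cccc21`, differs from compound 3 in one place: dimethylamino in place of chloro on an aromatic carbon. Going by the values given here, no measured step connects a chloro with a dimethylamino compound on this core, so the size and direction of the change from compound 3 cannot be read from the data; the step could be large in either direction or fall within the scatter.

Given that compound 1 with methyl at this site gives 1130 nM while the chloro analogue compound 3 had no activity, compound 4 is expected to return a value near 3000 nM in this assay, with a broad range from 500 nM to 20000 nM, and a real chance that only an inactive result is reported.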

Compound 4, half-maximal effective concentration: 7120 nM
Beside the measured number, compound 4's estimate is 2.4-fold (0.38 log units) below it; measured number inside the range.
By their numbers in this assay, from the lowest: compound 1; then compounds 2 and 4 (each within the scatter of the next).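

In this assay compound 4, with dimethylamino on this aromatic carbon, returns 7120 nM as a measurable number, so a measurable response at this site is not confined to the methyl group of compound 1. Dimethylamino in place of methyl gives a 6.3-fold higher number from compound 1 to compound 4 (0.80 log units; beyond the scatter) and thus a real but not drastic loss, which makes methyl the better of the two groups with numbers at this site. Compound 3, with chloro at the same site, gives "not active" (no number reported) and so the step from it to compound 4 cannot be read as a size, only as the contrast between no number and a number.

Nothing measured on these compounds explains why chloro and dimethylamino part ways at this site.

Going by these compounds, whether an unsubstituted amine or a methoxy group on this aromatic carbon would fall nearer compound 1 or nearer compound 4 stays open. Also open, on these data alone, is whether fluoro or bromo at this site would end up like the chloro group of compound 3, with no number, or would return a measurable value.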